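The compounds below may be only part of what the source reports. "The series", "measured", "known", "first", "only" and "open" are said of these compounds alone.

Compound 1 `COc1cc(-c2nn(-c3cccc(NC(=O)Nc4cc(C(F)(F)F)cc(C(F)(F)F)c4)c3)cc2-c2ccncc2)ccc1Cl` gives 2190 nM in a functional assay on IGROV-1 cells (Homo sapiens) for inhibition, read by sulforhodamine B assay, with a stated time of 48 h; a lower number here means a stronger inhibitor of growth, a higher number a weaker inhibitor of growth. Compound 2 `O=C(Nc1cccc(-n2cc(-c3ccncc3)c(-c3ccc(Cl)c(O)c3)n2)c1)Nc1cc(C(F)(F)F)cc(C(F)(F)F)c1` differs from compound 1 by hydrogen in place of methyl on an oxygen on an aromatic ring. In this assay compound 2 gives 3550 nM, a step of a 1.6-fold higher number from compound 1 to compound 2 (0.21 log units; within the scatter). Compound 3 `COc1cc(-c2nn(-c3cccc(NC(=O)Nc4ccc(Cl)c(C(F)(F)F)c4)c3)cc2-c2ccncc2)ccc1Cl` gives 4220 nM in this assay; the difference between the core of compound 1 and the core of compound 3 is not broken down here, and the two values lie within the scatter of each other. Compound 4 `O=C(Nc1cccc(-n2cc(-c3ccncc3)c(-c3ccc(Cl)c(O)c3)n2)c1)Nc1ccc(Cl)c(C(F)(F)F)c1` differs from compound 3 by hydrogen in place of methyl on an oxygen on an aromatic ring, the same kind of change as that from compound 1 to compound 2, at a place described in the same words. Because the step of a 1.6-fold higher number from compound 1 to compound 2 (0.21 log units; within the scatter) was within the scatter, the step from compound 3 to compound 4 is expected to be a 1.4-fold higher number from compound 3 to compound 4 (0.15 log units; within the scatter). Compound 4 is therefore estimated at 6000 nM, with a range from 2500 nM to 14000 nM.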

Compound 4, concentration for total growth inhibition: 2220 nM
Compound 4: middle estimate off by 2.7-fold (0.43 log units), on the high side, outside the stated range (below it).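

In this assay, the change from methoxy to hydroxy gives a 1.9-fold lower number from compound 3 to compound 4 (0.28 log units; within the scatter). Set beside the earlier step, this change did not carry over from one core to the other as a step of fixed size: the same change on two cores in this assay, a 1.6-fold higher number (0.21 log units; within the scatter) from compound 1 to compound 2 and a 1.9-fold lower number (0.28 log units; within the scatter) from compound 3 to compound 4, 3.1-fold (0.49 log units) apart, beyond the scatter of two such steps. Each step alone stays within the scatter, so this rests on the gap between them, and two pairs show neither a general rule for the series nor why the steps differ.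

The compounds shown leave open how the same change reads on further cores. They also leave open how an amine or a carboxylic acid in place of the hydroxy on the 4-chloro-3-hydroxyphenyl group would read in this assay.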